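The source may hold more compounds than are shown below. What is called first, only, known or untested is meant among the compounds shown, and "the series" means these compounds.

Working notes on the series.

Compound 1 `CC1=C(/C=C/C(=O)/C=C/c2ccccc2Cl)C(C)(C)CCC1` and compound 2 `CC1=C(/C=C/C(=O)/C=C/c2ccccc2[N+](=O)[O-])C(C)(C)CCC1` share the same core and differ only at one position on the aromatic ring. In a functional assay on IMR-32 cells (Homo sapiens) for cytotoxicity, read by sulforhodamine B assay, with a stated time of 48 h (on this read-out lower numbers stand for stronger inhibition and higher numbers for weaker inhibition), compound 1 gives 13700 nM. In this assay compound 2 gives 13500 nM. Among the compounds with values here, the one measured step in the set, nitro in place of chloro on an aromatic carbon, is a 1.0-fold lower number from compound 1 to compound 2 (0.01 log units; within the scatter), so compound 2 and compound 1 sit together within the scatter and neither can be set apart from the other on these numbers.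

Compound 3 `CC1=C(/C=C/C(=O)/C=C/c2ccccc2F)C(C)(C)CCC1` is not yet measured. It differs from compound 2 by fluoro in place of nitro on an aromatic carbon. Within the data shown here, the only step that bears on this change is the one from compound 1 to compound 2, which was within the scatter. On this basis no step beyond the scatter is expected in this assay, in either direction. The step from compound 2 to compound 3 is estimated as no change at the digits printed from compound 2 to compound 3 (within the scatter). Compound 3 is therefore expected to give about 13500 nM in this assay, with a range from 6000 nM to 30000 nM.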

Compound 3, half-maximal inhibitory concentration: 15600 nM
Estimate against measurement, compound 3: 1.2-fold (0.06 log units) below; measured number inside the range.
By their numbers in this assay, from the lowest: compounds 2, 1 and 3 (each within the scatter of the next).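

In this assay fluoro in place of nitro gives a 1.2-fold higher number from compound 2 to compound 3 (0.06 log units; within the scatter) and fluoro in place of chloro gives a 1.1-fold higher number from compound 1 to compound 3 (0.06 log units; within the scatter) at the same place, so a third group now stands on this aromatic carbon ortho to a large group and no order among the three can be drawn. Within the data shown here, the earlier pair showed only that chloro and nitro could not be told apart, whereas the new steps extend this to fluoro, which brings 1 heavy atom and 0 hydrogen-bond acceptors where nitro brings 3 heavy atoms and 2 hydrogen-bond acceptors, and still no step leaves the scatter. Nothing on hand speaks to why these three groups read alike.

The compounds shown leave open whether an amine, a carboxylic acid or a methoxy group at this place would also stay within the scatter of compound 2 or would produce the first step beyond it. They also leave open whether any change to the shared core outside this one position would move the number in this assay at all.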